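A permeability step from a difluorophenyl to a dimethylphenyl

The source may report more compounds than this note shows. Statements on the series, on what has been measured and on what is new or still open speak of the compounds shown alone.

This account follows a single change made to compound 1 `Cc1oc(-c2c(F)cccc2F)nc1CN1CCC(C(=O)NCCCN2C[C@H](C)C[C@H](C)C2)CC1` and asks what it may do in a physicochemical assay for permeability, using PAMPA; on this read-out lower numbers stand for lower permeability and higher numbers for higher permeability. Among the measured compounds shown here, compound 1 is the only compound of this small set with a number: in this assay compound 1 gives 82.4 10^-6 cm/s. Two companions are known by structure alone. For compound 2 `Cc1cccc(Cl)c1-c1nc(CN2CCC(C(=O)NCCCN3CCC(C)(C)CC3)CC2)c(C)o1` the entry in this assay reads "not determined" (no result reported). For compound 3 `Cc1cccc(Cl)c1-c1nc(CN2CCC(C(=O)NCCCN3CCC(C(C)C)CC3)CC2)c(C)o1` the entry in this assay reads "not determined" (no result reported). Compound 1 therefore has no neighbour against which its value can be ranked.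

The compound still to be measured is compound 4 `Cc1cc(C)cc(-c2nc(CN3CCC(C(=O)NCCCN4C[C@H](C)C[C@H](C)C4)CC3)c(C)o2)c1`. It differs from compound 1 in one place (3,5-dimethylphenyl in place of 2,6-difluorophenyl on an aromatic carbon); the remainder of the shared core of compound 1 is carried over unchanged.

No step between two measured compounds is available to calibrate such a swap, and the data give no measured reason to expect either a gain or a loss. The expectation is therefore a step from compound 1 to compound 4 of a 1.0-fold lower number from compound 1 to compound 4 (0.01 log units; within the scatter), which is no change beyond the usual scatter of the assay. On that basis compound 4 is estimated to give 80 10^-6 cm/s in this assay, within a range from 40 10^-6 cm/s to 150 10^-6 cm/s.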

Compound 4, apparent permeability: 864 10^-6 cm/s
Beside the measured number, compound 4's estimate is 11-fold (1.03 log units) below it; the measured number lies above the stated range.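

Among the compounds shown here, at the aromatic carbon of the five-membered aromatic ring with 1 nitrogen and 1 oxygen, the exchange of 2,6-difluorophenyl for 3,5-dimethylphenyl gives a 10-fold higher number from compound 1 to compound 4 (1.02 log units; beyond the scatter) in this assay and supplies the first readable step of this small set. It shows that this place is not silent on this read-out: the number moves well beyond the scatter even though the leaving and entering groups match in heavy-atom count, in their carbon-only six-membered aromatic ring and in their hydrogen-bond donor and acceptor counts. Nothing measured here explains why the number moves so far.

This one step joins the loss of the fluorine atoms, the arrival of the methyl groups and the change in where the substituents sit, so a plain phenyl group or a 2,6-dimethylphenyl group at the same carbon would be needed to pull these apart. Steps involving compound 2 and compound 3 cannot be read, so it remains open whether the same exchange would act alike alongside the different amine ends those two compounds carry.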